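A few compounds are considered here, and "the series" means these few. Any claim that something is new, unique, unknown or untested is made for them only; others in the source may bear on it.

The series shares one core, carried here by compound 1 `CCCc1ccc(CCc2cc3cn([C@H]4C[C@H](O)[C@@H](CO)O4)c(=O)nc3o2)cc1`, which is tested in an ADME assay on HEL cells (Homo sapiens) for cytotoxicity, with a stated time of 3 days; a lower number here means that less compound is tolerated, a higher number that more compound is tolerated. For compound 1 the result is only a limit of the measurement, given as >= 130000 nM. Two further compounds on the same core are measured in this assay. Compound 2 `CCCCCCCC/C=C/c1cc2cn([C@H]3C[C@H](O)[C@@H](CO)O3)c(=O)nc2o1` likewise reaches only a limit, >= 120000 nM. Compound 3 `CCCCCc1ccc(-c2cc3cn([C@H]4C[C@H](O)[C@@H](CO)O4)c(=O)nc3o2)cc1`, by contrast, stops at a much lower limit, > 1300 nM. None of the three gives a number inside the range of this assay, so compound 1 can only be said to sit at the upper edge of what was tested, together with compound 2, while compound 3 is reported at a far lower limit (the limit of > 1300 nM in this assay, at which 1 of the 3 values shown sits).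

Compound 4 `O=c1nc2oc(CCc3ccccc3)cc2cn1[C@H]1C[C@H](O)[C@@H](CO)O1` has not yet been measured in this assay. It differs from compound 1 in one place: hydrogen in place of propyl on an aromatic carbon. Among the compounds with values here, no measured pair in the set carries this kind of change, so the expected size of the step rests on the standing of compound 1 alone, which sits at the limit (the limit of >= 130000 nM in this assay, at which 1 of the 3 values shown sits). The step from compound 1 to compound 4 in this assay is expected to be a number no higher from compound 1 to compound 4 (the limit leaves the size open), that is, within the usual scatter and in no clear direction. For compound 4 the estimate in this assay is 130000 nM, with a likely range from 50000 nM to 300000 nM, and most probably again reported only as a limit.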

Compound 4, minimum cytotoxic concentration: > 560000 nM
Compound 4 was reported as a limit; the forecaster's own chance of this, stated with the estimate: 70%; middle value at least 4.3-fold (0.63 log units) from the limit.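

In this assay, compound 4 is reported only as a limit, > 560000 nM. Compound 1 is also reported only as a limit, >= 130000 nM, so no step can be read between compound 1 and compound 4. The compounds shown leave open whether hydrogen in place of propyl changes the minimum cytotoxic concentration at all.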